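The source may hold more compounds than are shown below. What is called first, only, known or untested is meant among the compounds shown, and "the series" means these compounds.

Measured so far, in a functional assay on KB cells (Homo sapiens), read by MTT assay; a higher number here means a weaker inhibitor, a lower number a stronger inhibitor:
Compound 1 `C#C[C@@H]1[C@@H](O)[C@H](n2ccc(=O)[nH]c2=O)O[C@@H]1CO` gives > 350000 nM, which is a limit of the assay and not a number.
Compound 2 `C=C[C@@]1(O)[C@@H](CO)O[C@@H](n2ccc(N)nc2=O)[C@@H]1O` gives 74300 nM.
Compound 3 `CC[C@@]1(O)[C@@H](CO)O[C@@H](n2ccc(N)nc2=O)[C@@H]1O` gives 258000 nM.

Compound 3 has the highest of the two numbers that were measured outright; the nearest is compound 2, separated by a 3.5-fold higher number from compound 2 to compound 3 (0.54 log units; beyond the scatter), a modest step beyond the scatter. Compound 4 `CC#C[C@@]1(O)[C@@H](CO)O[C@@H](n2ccc(N)nc2=O)[C@@H]1O` differs from compound 3 by prop-1-yn-1-yl in place of ethyl on a saturated ring carbon. Going by the values given here, the only measured step bearing on this change is a 3.5-fold higher number from compound 2 to compound 3 (0.54 log units; beyond the scatter), where ethyl in place of vinyl raised the number. Prop-1-yn-1-yl brings a triple bond, and compound 2 with vinyl gave 74300 nM, so a step back down of similar size is expected for compound 4, namely a 3.2-fold lower number from compound 3 to compound 4 (0.51 log units; beyond the scatter). Compound 4 is therefore estimated at 80000 nM, within 20000 nM to 300000 nM.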

Compound 4, half-maximal inhibitory concentration: 14600 nM
Estimate against measurement, compound 4: 5.5-fold (0.74 log units) above; the whole stated range lies above it.
By their numbers in this assay, from the lowest: compound 4; then compound 2; then compound 3. At a limit, above all of these: compound 1.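

In this assay, prop-1-yn-1-yl gives the lowest number of the three groups compared on this saturated ring carbon, with an 18-fold lower number from compound 3 to compound 4 (1.25 log units; beyond the scatter) and a 5.1-fold lower number from compound 2 to compound 4 (0.71 log units; beyond the scatter) as its steps. The number therefore does not simply return to the level seen with vinyl, as the group with the triple bond goes clearly past it. Nothing given here bears on the reason for this drop.

On these data alone, how a longer chain ending in or containing a triple bond, or an amine, would move the number at this carbon remains open.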